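The source may hold more compounds than are shown below. What is called first, only, known or untested is meant among the compounds shown, and "the series" means these compounds.

Of the compounds shown here, three have been measured in an ADME assay on MRC5 cells (Homo sapiens) for inhibition, with a stated time of 72 h; on this read-out higher numbers stand for an effect only at larger amounts of compound and lower numbers for an effect already at smaller amounts. Compound 1 `CO[C@H]1CC[C@H](NC(=O)c2n[nH]cc2NC(=O)c2ccc(N3CCCC3)cc2)CC1` gives > 50000 nM, which is a limit of the assay and not a number. Compound 2 `CO[C@H]1CC[C@H](NC(=O)c2n[nH]cc2NC(=O)c2cc3ccccn3n2)CC1` gives 1000 nM. Compound 3 `COc1cccc(OC)c1C(=O)Nc1c[nH]nc1C(=O)NN1CCOCC1` gives > 50000 nM, again only a limit of the assay. Compound 3 thus stands among the values reported only as a limit, alongside compound 1, while compound 2 alone shows an effect at an amount the assay could resolve.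

Compound 4 `COc1cccc(OC)c1C(=O)Nc1c[nH]nc1C(=O)NCc1ccccn1` has not yet been measured. It differs from compound 3 in one place: (pyridin-2-yl)methyl in place of morpholin-4-yl on an amide-type nitrogen. Among the measured compounds shown here, no pair of measured compounds that differ in one place is available, so the size of this kind of step in this assay cannot be read from the measured compounds. Compound 3 stands at the limit of > 50000 nM in this assay, at which 2 of the 3 values shown sit, so the step from compound 3 to compound 4 could register only as a move toward lower values, and none of the measured compounds gives a reason to expect such a move beyond the scatter.

Compound 4 is therefore expected to give about 50000 nM, within a range from 20000 nM to 120000 nM, and most likely to be reported again only as a limit. This expectation amounts to an estimated step of a number no higher from compound 3 to compound 4 (the limit leaves the size open).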

Compound 4, half-maximal effective concentration: > 50000 nM
Compound 4 ended at the assay's limit (the forecaster's own chance of this, stated with the estimate: 75%); the middle value lies on the limit itself.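

Among the compounds shown here, compound 3 and compound 4 are both reported only as a limit, so no step between them can be read, and the exchange of morpholin-4-yl for (pyridin-2-yl)methyl remains without a size: the limit of > 50000 nM in this assay, at which 3 of the 4 values shown sit. The compounds shown leave open where compound 3 and compound 4 truly lie and whether they differ at all.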